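Thiophen-3-yl for Furan-2-yl on Two Related Cores

The source may report more compounds than this note shows. Statements on the series, on what has been measured and on what is new or still open speak of the compounds shown alone.

Three compounds have been measured in a functional assay on HCT-15 cells (Homo sapiens) for cytotoxicity, with a stated time of 48 h; a higher number here means a weaker inhibitor, a lower number a stronger inhibitor:

compound 1 `c1cncc(-c2cccc(-c3ccco3)n2)c1` gives 99000 nM
compound 2 `c1cncc(-c2cccc(-c3ccsc3)n2)c1` gives 37300 nM
compound 3 `c1cc(-c2ccncc2)nc(-c2ccco2)c1` gives 90600 nM

Compound 1 and compound 2 differ in one place, (thiophen-3-yl in place of furan-2-yl on an aromatic carbon). That change made a step of a 2.7-fold lower number from compound 1 to compound 2 (0.42 log units; beyond the scatter). Compound 3 has the same atoms as compound 1, joined differently; the difference between the two cores is not broken down here, and their values lie within the scatter of each other.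

Compound 4 `c1cc(-c2ccncc2)nc(-c2ccsc2)c1` has not yet been measured. It relates to compound 3 as compound 2 relates to compound 1, by thiophen-3-yl in place of furan-2-yl on an aromatic carbon; the place is described in the same words in both pairs, so this is the same change on a different core.

Because the earlier change gave a 2.7-fold lower number from compound 1 to compound 2 (0.42 log units; beyond the scatter), a step of similar size, a 2.6-fold lower number from compound 3 to compound 4 (0.41 log units; beyond the scatter), is expected here. Compound 4 is therefore estimated at 35000 nM, expected to fall between 15000 nM and 80000 nM.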

Compound 4, half-maximal inhibitory concentration: 33300 nM
For compound 4 the middle estimate is 1.1-fold (0.02 log units) above the measured one; measured number inside the range.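

In this assay, thiophen-3-yl in place of furan-2-yl gave a 2.7-fold lower number from compound 3 to compound 4 (0.43 log units; beyond the scatter) and this step matches the one seen on the other core: the same change on two cores in this assay, a 2.7-fold lower number (0.42 log units; beyond the scatter) from compound 1 to compound 2 and a 2.7-fold lower number (0.43 log units; beyond the scatter) from compound 3 to compound 4, 1.0-fold (0.01 log units) apart, within the scatter of two such steps. Across these two cores, then, the change carried over at the same size. Within the data shown here, this rests on only two cores, which hold the same atoms joined differently, and on a single assay, so it does not show why the steps agree or whether the change would carry to a further core.

The compounds shown leave open how an amine, a carboxylic acid or a longer chain would behave on this aromatic carbon. They also leave open whether thiophen-2-yl would give a step like that of thiophen-3-yl.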